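Solubility notes: from compound 3 to compound 4

The compounds below may be only part of what the source reports. "The series", "measured", "known", "first", "only" and "open" are said of these compounds alone.

Measured in a physicochemical assay for solubility, in phosphate buffer, measured as kinetic solubility, at pH 7.4; a lower number here means a less soluble compound, a higher number a more soluble compound:
- Compound 1 `Cc1ccc(C)c(-c2nc(CN3CCC(C(=O)NCCCN4C[C@H](C)C[C@H](C)C4)CC3)c(C)o2)c1`: 56.1 ug/mL
- Compound 2 `Cc1oc(-c2ccc(Cl)cc2)nc1CN1CCC(C(=O)NCCCN2C[C@H](C)C[C@H](C)C2)CC1`: > 72 ug/mL (a limit, not a number)
- Compound 3 `Cc1oc(-c2c(F)cccc2F)nc1CN1CCC(C(=O)NCCCN2C[C@H](C)C[C@H](C)C2)CC1`: > 72 ug/mL (a limit, not a number)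

Compound 3 has no number and stands at the limit of > 72 ug/mL in this assay, at which 2 of the 3 values shown sit. Compound 4 `Cc1oc(-c2c(Br)cccc2Br)nc1CN1CCC(C(=O)NCCCN2C[C@H](C)C[C@H](C)C2)CC1` carries 2,6-dibromophenyl in place of 2,6-difluorophenyl on an aromatic carbon of a five-membered aromatic ring with 1 nitrogen and 1 oxygen (2,6-dibromophenyl in place of 2,6-difluorophenyl on an aromatic carbon).

For the measured compounds named here, three measured steps concern this same place: an at least 1.2-fold higher number from compound 1 to compound 2 (0.10 log units; that floor lies within the scatter), an at least 1.2-fold higher number from compound 1 to compound 3 (0.10 log units; that floor lies within the scatter) and a step that the two limits leave unreadable from compound 2 to compound 3. The first two are floors within the scatter and the third cannot be read, so none gives a size for replacing fluorine with bromine. No step beyond the scatter is expected in this assay. Going by the values given here, compound 1, the only compound with a number, gives 56.1 ug/mL, and the expectation leans towards it. The estimated change is an at least 1.2-fold lower number from compound 3 to compound 4 (0.07 log units; that floor lies within the scatter). For compound 4 the estimate is 60 ug/mL, with an expected range from 30 ug/mL to 85 ug/mL.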

Compound 4, solubility: 62.4 ug/mL
For compound 4 the middle estimate is 1.0-fold (0.02 log units) below the measured one, and the stated range covers the measured number.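

In this assay, 2,6-dibromophenyl gives this position a second number rather than a limit, and the comparison with 2,5-dimethylphenyl is a 1.1-fold higher number from compound 1 to compound 4 (0.05 log units; within the scatter), so these two groups cannot be told apart here. Against the two limits, the steps are an at least 1.1-fold lower number from compound 3 to compound 4 (0.06 log units; that floor lies within the scatter) and an at least 1.1-fold lower number from compound 2 to compound 4 (0.06 log units; that floor lies within the scatter), so neither 2,6-difluorophenyl nor 4-chlorophenyl shows a readable separation from 2,6-dibromophenyl. Compound 2 and compound 3 still carry a limit and not a number, which leaves the true size of both steps unknown: the limit of > 72 ug/mL in this assay, at which 2 of the 4 values shown sit.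

As far as these compounds go, how far compound 2 and compound 3 actually lie from compound 4 stays open. Also open, from the compounds shown here alone, is whether a phenyl bearing an amine or a carboxylic acid at this position would give a step beyond the scatter.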